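HDAC6 inhibition: a hydroxy group replaced by 2-aminophenyl

A few compounds are considered here, and "the series" means these few. Any claim that something is new, unique, unknown or untested is made for them only; others in the source may bear on it.

Of the compounds shown here, two with the same core have been measured in an assay on isolated protein for inhibition of protein deacetylase HDAC6 (Homo sapiens), with a stated time of 15 min; a lower number here means a stronger inhibitor, a higher number a weaker inhibitor. Compound 1 `Nc1nc(NCc2ccc(C(=O)NO)cc2)nc2nc(-c3ccco3)nn12` gives 3 nM. Compound 2 `Nc1nc(NCCOc2ccc(C(=O)NO)cc2)nc2nc(-c3ccco3)nn12` gives 3.2 nM, which is the higher of the two numbers, yet it lies within the scatter of compound 1, so the two cannot be told apart on these data.

Compound 3 `Nc1ccccc1NC(=O)c1ccc(OCCNc2nc(N)n3nc(-c4ccco4)nc3n2)cc1` has not been measured in this assay. It differs from compound 2 in one place: 2-aminophenyl in place of hydroxy on an amide-type nitrogen. The hydroxamic acid that compounds 1 and 2 share is thus gone, and a (2-aminophenyl)carbamoyl group stands in its place.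

For the measured compounds named here, no measured pair in this set shows what such a change does, so any expectation rests on the change itself rather than on a step between measured compounds. The account here expects a large loss of inhibition, well beyond the scatter, with the number for compound 3 rising far above that of compound 2, the expected step being a 630-fold higher number from compound 2 to compound 3 (2.80 log units; beyond the scatter). The estimate for compound 3 in this assay is 2000 nM, with a range from 300 nM to 20000 nM.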

Compound 3, half-maximal inhibitory concentration: > 10000 nM
Compound 3: no number, only a limit; the forecaster's own chance of this, stated with the estimate: 20%; middle value at least 5.0-fold (0.69 log units) from the limit.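

In this assay compound 3 gives > 10000 nM, which is a limit of the assay and not a number. Compounds 1 and 2 both carry the hydroxycarbamoyl group and so said nothing about this position, whereas the change from hydroxy to 2-aminophenyl on the amide-type nitrogen now gives an at least 3100-fold higher number from compound 2 to compound 3 (3.49 log units; beyond the scatter), which shows that inhibition depends strongly on what sits on that nitrogen. The group that leaves and the group that enters have the same count of hydrogen-bond donors and acceptors, so that count alone does not preserve inhibition here, and the true size of the loss stays unknown, since the step rests on a limit: the limit of > 10000 nM in this assay, at which 1 of the 3 values shown sits.

The compounds shown do not separate the loss of the hydroxy group from the arrival of the 2-aminophenyl group, since both happen in the same single change. From the compounds shown here alone, it also remains open how inhibition would respond to a smaller group on that nitrogen, such as methoxy or a plain amine, or to a carboxylic acid in place of the whole hydroxycarbamoyl group.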